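The compounds below may be only part of what the source reports. "The series", "measured", "known", "first", "only" and "open" are said of these compounds alone.

Compound 1 `ClCc1ccccc1Cn1cnc2c(Cl)nc(Cl)nc21` and compound 2 `ClCc1cccc(Cn2cnc3c(Cl)nc(Cl)nc32)c1` share the same atoms joined differently; the difference between the two cores is not broken down here. In a functional assay on TK-10 cells (Homo sapiens) for cytotoxicity, read by sulforhodamine B assay, with a stated time of 48 h (on this read-out lower numbers stand for higher toxicity in this test and higher numbers for lower toxicity in this test), compound 1 gives 5620 nM. In this assay compound 2 gives 8910 nM, and these two numbers lie within the usual scatter of each other. Compound 3 `Nc1nc(Cl)c2ncn(Cc3ccccc3CCl)c2n1` carries the change amino in place of chloro on an aromatic carbon relative to compound 1, and in this assay compound 3 gives 75900 nM; this change made a 14-fold higher number from compound 1 to compound 3 (1.13 log units; beyond the scatter).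

Compound 4 `Nc1nc(Cl)c2ncn(Cc3cccc(CCl)c3)c2n1` is not yet measured. It stands to compound 2 as compound 3 stands to compound 1: the change is amino in place of chloro on an aromatic carbon, and the surroundings of the place are described in the same words for both pairs, so it is the same change on a different core. Since the step from compound 1 to compound 3 was a 14-fold higher number from compound 1 to compound 3 (1.13 log units; beyond the scatter), the step from compound 2 to compound 4 is expected to be similar, estimated at a 14-fold higher number from compound 2 to compound 4 (1.15 log units; beyond the scatter). Among the measured compounds shown here, on that basis compound 4 is expected to give about 125000 nM in this assay, with a range from 50000 nM to 300000 nM considered plausible given the single precedent.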

Compound 4, concentration lethal to 50% of the cells: 27500 nM
Compound 4: the middle estimate sits 4.5-fold (0.66 log units) above what was measured; the whole stated range lies above it.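

In this assay the change of amino in place of chloro on an aromatic carbon again goes with a higher number, with a step of a 3.1-fold higher number from compound 2 to compound 4 (0.49 log units; beyond the scatter). The direction of the change therefore carries from one core to the other, but its size does not: the same change on two cores in this assay, a 14-fold higher number (1.13 log units; beyond the scatter) from compound 1 to compound 3 and a 3.1-fold higher number (0.49 log units; beyond the scatter) from compound 2 to compound 4, 4.4-fold (0.64 log units) apart, beyond the scatter of two such steps. This shows that the earlier step gave the sign on the second core but not a size that could be transferred, and with two pairs it does not show what sets the size or how the change would behave on any further core.

The compounds shown leave open whether a methylamino or a methoxy group on the same aromatic carbon would give a step like that of amino. They also leave open whether the two steps would stay apart if a bromomethyl or a plain methyl group stood in place of the chloromethyl group.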